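The source may report more compounds than this note shows. Statements on the series, on what has been measured and on what is new or still open speak of the compounds shown alone.

Series notes. In a functional assay on NCI/ADR-RES cells (Homo sapiens) for antiproliferative activity (on this read-out lower numbers stand for stronger inhibition of growth and higher numbers for weaker inhibition of growth), compound 1 `COc1cccc(-c2nn(-c3ccccc3)cc2-c2ccnc(NCCCNC(=O)c3cccc(C(F)(F)F)c3)c2)c1` gives 3540 nM, and compound 2 `COc1cccc(-c2nn(-c3ccccc3)cc2-c2ccnc(NCCNC(=O)Nc3cccc(C(F)(F)F)c3)c2)c1` gives 2220 nM. Compound 3 `O=C(NCCCNc1cc(-c2cn(-c3ccccc3)nc2-c2cccc(O)c2)ccn1)c1ccccc1` gives 2670 nM in this assay. Among these three numbers compound 3 stands second highest; the nearest is compound 2, whose number is lower by a margin within the scatter, and the furthest is compound 1, whose number is higher by a margin that is also within the scatter. On the values shown, the three compounds are not separated from one another in this assay.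

Compound 4 `O=C(NCCCNc1cc(-c2cn(-c3ccccc3)nc2-c2cccc(O)c2)ccn1)c1ccc(F)cc1` is not yet measured. It differs from compound 3 by fluoro in place of hydrogen on an aromatic carbon. No step between measured compounds in this series reads on the same change, so there is nothing in the shown numbers to set a direction for it. The expectation is that the step from compound 3 to compound 4 in this assay, a 1.1-fold lower number from compound 3 to compound 4 (0.03 log units; within the scatter), stays within the scatter, with no clear direction. For compound 4 the estimate in this assay is 2500 nM, with a range from 1100 nM to 5500 nM.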

Compound 4, concentration for 50% growth inhibition: 2200 nM
Compound 4: middle estimate off by 1.1-fold (0.06 log units), on the high side, and the stated range covers the measured number.
By their numbers in this assay, from the lowest: compounds 4, 2, 3 and 1 (each within the scatter of the next).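

In this assay, for the compounds shown here, the first one-place comparison reads a 1.2-fold lower number from compound 3 to compound 4 (0.08 log units; within the scatter) and so does not separate the pair. At this aromatic carbon, para to a large group, phenyl to 4-fluorophenyl leaves growth inhibition unresolved from that of the parent, and this single step sets no direction for the position. No data are at hand to explain this result.

The compounds shown leave open whether a different group at the same carbon, such as an amine, a carboxylic acid or a methoxy group, would give a step beyond the scatter. Also open, going by these compounds, is whether fluoro at other carbons of this ring, or on the phenyl group attached to the core, would read the same way.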